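Chloro for methyl on a urea anticonvulsant scaffold

The compounds below may be only part of what the source reports. "The series", "measured", "known", "first", "only" and "open" are said of these compounds alone.

The account concerns two measured ureas and one not yet tested. In a functional assay on the whole organism with Mus musculus as the target, in the maximal electroshock model, with a stated time of 30 min (on this read-out lower numbers stand for an effect already at smaller amounts and higher numbers for an effect only at larger amounts of compound), compound 1 `Cc1cccc(Cl)c1NC(=O)Nc1ccncc1` gives 30 mg/kg. Among the measured compounds shown here, compound 2 `Cc1cccc(C)c1NC(=O)Nc1ccccn1` differs from compound 1 in several places; in this assay compound 2 gives 300 mg/kg and so stands with the highest number of the two; the gap between the two values lies well beyond the scatter, though with only two compounds no single cause can be read from it.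

Compound 3 `Cc1cccc(Cl)c1NC(=O)Nc1ccccn1` is the untested member. It differs from compound 2 in one place only: chloro in place of methyl on an aromatic carbon. For the measured compounds named here, compound 1, the only compound that carries the chloro group, is the one with the lower number, and this is the sole guide available.

He therefore expects compound 3 to move toward a lower number than compound 2, with a step of a 3.0-fold lower number from compound 2 to compound 3 (0.48 log units; beyond the scatter) in this assay, because compound 1 gives 30 mg/kg. The estimate for compound 3 is 100 mg/kg, with a range from 30 mg/kg to 300 mg/kg, the wide span reflecting that compound 1 and compound 2 also differ elsewhere.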

Compound 3, minimum effective dose: 100 mg/kg
Estimate against measurement, compound 3: no gap at the digits printed; measured number inside the range.
By their numbers in this assay, from the lowest: compound 1; then compound 3; then compound 2.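

In this assay, the replacement of methyl by chloro on an aromatic carbon, ortho to a large group, can now be read on its own: with the pyridin-2-yl group held constant, it gives a 3.0-fold lower number from compound 2 to compound 3 (0.48 log units; beyond the scatter). The result also isolates a second place, since pyridin-2-yl in place of pyridin-4-yl on an amide-type nitrogen, with the chloro group held constant, gives a 3.3-fold higher number from compound 1 to compound 3 (0.52 log units; beyond the scatter). Each of these modest single changes lies beyond the scatter, so both the chloro group and the position of the ring nitrogen matter to the read-out in these compounds, in opposite directions for the changes as written, but the data give no reason for either step.

The compounds shown leave open how a bromine atom, a methoxy group or an amine would behave in the place now held by chloro, and so whether the lower number is particular to chloro. They also leave open whether the step from methyl to chloro would have the same size with pyridin-4-yl on the urea, and what a change at the remaining methyl group would do.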